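Replacing the pyridin-3-yl group of compound 3

This account rests on a few compounds, and the source may have more. Where it says the series, first, only, none or still open, it means among the compounds named here.

Compound 1 `CC(=O)OCC(=O)OCCc1c(-c2ccccc2Cl)c2cc(Cl)ccc2[nH]c1=O` gives 100000 nM
Compound 2 `O=C(OCCc1c(-c2ccccc2Cl)c2cc(Cl)ccc2[nH]c1=O)C1CCCCC1` gives 38000 nM
Compound 3 `O=C(OCCc1c(-c2ccccc2Cl)c2cc(Cl)ccc2[nH]c1=O)c1cccnc1` gives 170000 nM

These values come from an ADME assay on HepG2 2.2.15 cells (Homo sapiens) for cytotoxicity (a lower number here means that less compound is tolerated, a higher number that more compound is tolerated), and the three compounds differ only in the group on a carbonyl carbon. Compound 3 stands level with compound 1 (a 1.7-fold higher number from compound 1 to compound 3 (0.23 log units; within the scatter)) and clear of compound 2 (a 4.5-fold higher number from compound 2 to compound 3 (0.65 log units; beyond the scatter)).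

The unmeasured compound 4 `O=C(/C=C/c1cccc(F)c1)OCCc1c(-c2ccccc2Cl)c2cc(Cl)ccc2[nH]c1=O` has 2-(3-fluorophenyl)ethenyl in place of pyridin-3-yl on a carbonyl carbon. Within the data shown here, no measured step makes this exact swap, so the evidence is indirect. Compound 2, whose cyclohexyl is the only other ring in the set, has the lowest number, and a second step agrees (a 2.6-fold lower number from compound 1 to compound 2 (0.42 log units; beyond the scatter)). Compound 1 goes against any simple rule that losing pyridin-3-yl lowers the number, since it carries no such ring and still sits level with compound 3. A modest fall is therefore expected, though three compounds make a thin guide. The expected change is (a 3.1-fold lower number from compound 3 to compound 4 (0.49 log units; beyond the scatter)). The estimated value for compound 4 is 55000 nM (range 18000 nM to 150000 nM).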

Compound 4, half-maximal cytotoxic concentration: > 1600000 nM
Compound 4 ended at the assay's limit; the forecaster's own chance of this, stated with the estimate: 15%; at least 29-fold (1.46 log units) between middle value and limit.
By their numbers in this assay, from the lowest: compound 2; then compounds 1 and 3 (each within the scatter of the next). At a limit, above all of these: compound 4.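

In this assay compound 4 gives > 1600000 nM, which is a limit of the assay and not a number: the limit of > 1600000 nM in this assay, at which 1 of the 4 values shown sits.

The 2-(3-fluorophenyl)ethenyl group stands clear of all three earlier groups on this carbonyl carbon, with an at least 9.4-fold higher number from compound 3 to compound 4 (0.97 log units; beyond the scatter), an at least 16-fold higher number from compound 1 to compound 4 (1.20 log units; beyond the scatter) and an at least 42-fold higher number from compound 2 to compound 4 (1.62 log units; beyond the scatter). Among these compounds, this place can therefore shift the tolerated concentration much further than the earlier compounds showed, where the widest step was a 4.5-fold higher number from compound 2 to compound 3 (0.65 log units; beyond the scatter).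

The compounds shown leave open which part of the new group goes with this shift: the double bond, the fluorine or the benzene ring. A plain 2-phenylethenyl group, or a saturated 2-(3-fluorophenyl)ethyl chain, would begin to separate these parts.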